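One Added Methyl on a Saturated Ring

The source may hold more compounds than are shown below. What is called first, only, known or untested is meant among the compounds shown, and "the series" means these compounds.

Compound 1 (`CN1CCN(c2cc(CN(C)C3CCCc4cccnc43)nc(C3CC3)n2)CC1`): 0.017 h
Compound 2 (`Cc1nc(CN(C)[C@H]2CCCc3cccnc32)cc(N2CCN(C)[C@@H](C)C2)n1`): 0.0267 h

In an ADME assay on microsomes from liver (Rattus norvegicus) for metabolic stability, read by LC-MS, using NADPH, with stated times of 10 min and 60 min (a lower number here means that the compound disappears faster, a higher number that the compound lasts longer), compound 2 stands within the usual scatter of compound 1, so the two cannot be ranked. Compound 3 (`Cc1nc(CN(C)[C@H]2CCCc3cccnc32)cc(N2C[C@@H](C)N(C)[C@@H](C)C2)n1`) differs from compound 2 by methyl in place of hydrogen on a saturated ring carbon, turning 3,4-dimethylpiperazin-1-yl into 3,4,5-trimethylpiperazin-1-yl. Among the measured compounds shown here, no measured pair shows what such a change does. The expected 1.1-fold lower number from compound 2 to compound 3 (0.03 log units; within the scatter) stays within the scatter, in neither direction. For compound 3 the estimated half-life is 0.025 h, with an expected range from 0.012 h to 0.05 h.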

Compound 3, half-life: < 0.0167 h
Compound 3: no number, only a limit; the forecaster's own chance of this, stated with the estimate: 5%; middle value at least 1.4-fold (0.17 log units) from the limit.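

Among the compounds shown here, the added methyl, which turns 3,4-dimethylpiperazin-1-yl into 3,4,5-trimethylpiperazin-1-yl, gives the first measured step for this change in this assay: an at least 1.5-fold lower number from compound 2 to compound 3 (0.20 log units; that floor lies within the scatter). The result for compound 3 is a limit of the assay, not a number: the limit of < 0.0167 h in this assay, at which 1 of the 3 values shown sits. As far as these compounds go, the methyl on this saturated ring carbon therefore gives no sign of a longer half-life, though the true size of the step remains unknown.

From the compounds shown here alone, it remains open whether an ethyl group, a hydroxyl or an amine on the same ring carbon would behave in the same way.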